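The source may report more compounds than this note shows. Statements on the series, on what has been measured and on what is new or still open speak of the compounds shown alone.

Compound 3 `CC1(C[C@@H](O)C(=O)N2C[C@H]3C[C@H]3[C@H]2C(=O)NCc2cc(Cl)ccc2-n2cnnn2)CC1` is the starting point, and in an ADME assay on liver for metabolic stability, with Liver microsome (Homo sapiens) as the target, read by LC-MS, using microsomes (a lower number here means slower removal, a higher number faster removal of the compound), compound 3 gives 12 mL.min-1.g-1. Compound 1 `CC(C)(C)[C@@H](O)C(=O)N1[C@@H]2C[C@@H]2C[C@H]1C(=O)NCc1cc(Cl)ccc1-n1cnnn1` gives 54 mL.min-1.g-1 in this assay, a higher number by a gap beyond the usual scatter, so compound 3 holds the lower of the two measured numbers. Compound 2 `CC(C)(C)[C@@H](O)C(=O)N1OCC[C@H]1C(=O)NCc1cc(Cl)ccc1-n1cnnn1` gives < 12 mL.min-1.g-1 in this assay, which is a limit of the assay and not a number. Compound 4 `O=C(NCc1cc(Cl)ccc1-n1cnnn1)[C@@H]1[C@@H]2C[C@@H]2CN1C(=O)[C@H](O)c1ccccc1` has not yet been measured; it differs from compound 3 by phenyl in place of (1-methylcyclopropyl)methyl on a saturated chain carbon bound to a carbonyl carbon and an oxygen on a saturated carbon. Within the data shown here, no measured pair makes this change, so its direction is open, and a shift within the scatter or a modest rise is expected. The estimate for compound 4 in this assay is 18 mL.min-1.g-1, with a range from 7 mL.min-1.g-1 to 45 mL.min-1.g-1, meaning an expected step of a 1.5-fold higher number from compound 3 to compound 4 (0.18 log units; within the scatter) that stays within the scatter.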

Compound 4, intrinsic clearance in microsomes: < 15 mL.min-1.g-1
Compound 4: a limit, no number (the forecaster's own chance of this, stated with the estimate: 25%); at least 1.2-fold (0.07 log units) between middle value and limit.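

Compound 4 gives < 15 mL.min-1.g-1, which is a limit and not a number, so the step from compound 3 to compound 4 cannot be read. The compounds shown leave open how far, and in which direction, phenyl in place of (1-methylcyclopropyl)methyl shifts intrinsic clearance in microsomes.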